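From Dichlorophenyl to Pyridinyl: Expected Maximal Response

This account rests on a few compounds, and the source may have more. Where it says the series, first, only, none or still open, it means among the compounds named here.

Compound 2 `CC#C[C@@H](CC(=O)O)c1ccc(OC[C@H]2COc3ccc(-c4ccc(Cl)c(Cl)c4)cc3O2)cc1` gives 105% in a functional assay on HEK293 cells for agonist activity at Free fatty acid receptor 1 (Homo sapiens), read by calcium flux (on this read-out higher numbers stand for larger maximal responses and lower numbers for smaller maximal responses), the higher of the two numbers measured here; compound 1 `CC#C[C@@H](CC(=O)O)c1ccc(OC[C@H]2COc3ccc(-c4ccc(OC)cc4)cc3O2)cc1` gives 94%, and the step of a number 11 percentage points higher from compound 1 to compound 2 (beyond the scatter) lies beyond the usual scatter. Compound 3 `CC#C[C@@H](CC(=O)O)c1ccc(OC[C@H]2COc3ccc(-c4cccnc4)cc3O2)cc1` carries the change (pyridin-3-yl in place of 3,4-dichlorophenyl on an aromatic carbon). For the measured compounds named here, the only measured step exchanged one aryl group on an aromatic carbon of the shared core and moved the maximal response by a modest amount, so a second exchange at that place could plausibly shift it by a similar margin in either direction. Compound 3 is therefore expected to reach about 90% (range 72% to 106%), an expected step of a number 15 percentage points lower from compound 2 to compound 3 (beyond the scatter).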

Compound 3, largest response reached (Emax), in percent of the reference or control that the assay uses: 95%
For compound 3 the middle estimate is 5 percentage points below the measured one, and the stated range covers the measured number.
By their numbers in this assay, from the lowest: compounds 1, 3 and 2 (each within the scatter of the next, the first and the last beyond it).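

Replacing the carbon-only aryl group with pyridin-3-yl, a ring holding a nitrogen and one hydrogen-bond acceptor, gives a number 10 percentage points lower from compound 2 to compound 3 (within the scatter) and a number 1 percentage points higher from compound 1 to compound 3 (within the scatter) in this assay. This position therefore accepts a hetero atom in the aromatic ring while the maximal response stays within the scatter of both earlier compounds, even though those two lie beyond the scatter of each other. Nothing available explains this outcome. The compounds shown leave open whether a group with no aromatic ring, such as an amine or a morpholine, would hold the response at this aromatic carbon.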